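From 4-Chlorophenyl to 2-Chlorophenyl on a Sulfonyl Sulfur

A few compounds are considered here, and "the series" means these few. Any claim that something is new, unique, unknown or untested is made for them only; others in the source may bear on it.

Three sulfonamides that share one core have been tested in an ADME assay on HEK293 cells (Homo sapiens) for cytotoxicity, read by resazurin assay, with a stated time of 48 h; on this read-out lower numbers stand for higher toxicity in this test and higher numbers for lower toxicity in this test. There, compound 1 `Cc1ccccc1S(=O)(=O)Nc1ccc2oc(-c3ccccc3)nc2c1` gives 57000 nM, compound 2 `O=S(=O)(Nc1ccc2oc(-c3ccccc3)nc2c1)c1ccccc1F` gives 72000 nM and compound 3 `O=S(=O)(Nc1ccc2oc(-c3ccccc3)nc2c1)c1ccc(Cl)cc1` gives 65000 nM. Compound 3 therefore sits level with both of the others, since its values lie within the usual scatter of repeated measurements.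

The next compound, compound 4 `O=S(=O)(Nc1ccc2oc(-c3ccccc3)nc2c1)c1ccccc1Cl`, keeps the same atoms but joins them differently: 2-chlorophenyl in place of 4-chlorophenyl on a sulfonyl sulfur. Going by the values given here, no measured pair makes exactly this swap, so the nearest evidence comes from the group on the sulfonyl sulfur in the three tested compounds. Replacing 2-methylphenyl with 4-chlorophenyl gives a 1.1-fold higher number from compound 1 to compound 3 (0.06 log units; within the scatter). Replacing 2-fluorophenyl with 4-chlorophenyl gives a 1.1-fold lower number from compound 2 to compound 3 (0.04 log units; within the scatter). Replacing the methyl of 2-methylphenyl with fluoro gives a 1.3-fold higher number from compound 1 to compound 2 (0.10 log units; within the scatter). All three steps are small and within the scatter, so these compounds give no reason to favour a direction.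

The expected change is no change at the digits printed from compound 3 to compound 4 (within the scatter), which is estimated to stay within the scatter. For compound 4 the expected value is 65000 nM, with an estimated range from 40000 nM to 100000 nM.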

Compound 4, half-maximal cytotoxic concentration: 73000 nM
Compound 4: the middle estimate sits 1.1-fold (0.05 log units) below what was measured; the range from low to high includes it.
By their numbers in this assay, from the lowest: compounds 1, 3, 2 and 4 (each within the scatter of the next).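

Going by these compounds alone, this is the first direct comparison of the same chlorine-bearing group joined in two different ways. In this assay, 2-chlorophenyl in place of 4-chlorophenyl on a sulfonyl sulfur gives a 1.1-fold higher number from compound 3 to compound 4 (0.05 log units; within the scatter), so the two arrangements cannot be told apart in this test. Changing only the group on the aromatic carbon tells the same story, with chloro in place of fluoro giving a 1.0-fold higher number from compound 2 to compound 4 (0.01 log units; within the scatter) and chloro in place of methyl giving a 1.3-fold higher number from compound 1 to compound 4 (0.11 log units; within the scatter), so that across these compounds neither the choice among these groups nor the change from 4-chlorophenyl to 2-chlorophenyl yields a step beyond the scatter, and no measured evidence is available to explain this result.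

As far as these compounds go, the phenyl groups on the sulfonyl sulfur in these compounds carry only methyl, fluoro or chloro, so it remains open whether an amine, a carboxylic acid or a longer chain at that place would leave the number within the scatter. From the compounds shown here alone, it is also open whether changes to the shared core would give an equally even set of values.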